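The source may hold more compounds than are shown below. What is called first, only, known or untested is meant among the compounds shown, and "the series" means these compounds.

Measured so far:
compound 1 `OCC(O)Cn1nc2c(Br)c(Br)c(Br)c(Br)c2n1` — 156%
compound 2 `OC(CCn1nc2c(Br)c(Br)c(Br)c(Br)c2n1)c1ccc(Br)cc1` — 59%
compound 3 `OC(CCn1nc2c(Br)c(Br)c(Br)c(Br)c2n1)c1ccccc1` — 99%

Three compounds share the core of compound 1 and carry different side chains. In a functional assay on MCF7 cells (Homo sapiens) for antiproliferative activity, read by MTT assay, with a stated time of 24 h, tested at 25 uM (a higher number here means a weaker effect of the compound at the concentration tested, a lower number a stronger effect), compound 1 gives 156%, compound 2 gives 59% and compound 3 gives 99%. Compound 3 stands second highest of the three: its nearest neighbour is compound 2, a number lower and beyond the scatter, while compound 1 lies furthest away, higher and also beyond the scatter.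

Compound 4 `OC(CCn1nc2c(Br)c(Br)c(Br)c(Br)c2n1)c1cccc(Cl)c1` is not yet measured. Against compound 3 the difference is chloro in place of hydrogen on an aromatic carbon.

Among the compounds with values here, one measured step bears on this change: a number 40 percentage points higher from compound 2 to compound 3 (beyond the scatter), where a halogen on the aromatic carbon leaves. Read in the opposite direction, a halogen entering the same six-membered ring went with a lower number. Compound 4 takes chloro rather than bromo, and at a different place on the ring, so the size of the step is uncertain, but the direction is expected to be downward in this assay, beyond the scatter.

Compound 4 is therefore expected to give about 75%, with a range from 50% to 105%; the expected step is a number 24 percentage points lower from compound 3 to compound 4 (beyond the scatter).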

Compound 4, a percentage reported as activity, at one concentration (the size of the read-out at that concentration, not a potency): 96%
Estimate against measurement, compound 4: 21 percentage points below; the range from low to high includes it.
By their numbers in this assay, from the lowest: compound 2; then compounds 4 and 3 (each within the scatter of the next); then compound 1.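

In this assay, chloro in place of hydrogen on the phenyl ring gives a number 3 percentage points lower from compound 3 to compound 4 (within the scatter), so 3-chlorophenyl and phenyl on this chain carbon cannot be told apart, and a halogen on this ring does not in itself go with a lower number. Setting 3-chlorophenyl in place of 4-bromophenyl gives a number 37 percentage points higher from compound 2 to compound 4 (beyond the scatter), which leaves compound 2 , at 59%, as the only one of the three aryl compounds set apart from the others by a step beyond the scatter. Nothing available explains the difference between the two halogenated compounds.

Compounds 2 and 4 differ both in the halogen and in its place on the ring, so these compounds cannot show which of the two carries the large step. From the compounds shown here alone, how an amine or a carboxylic acid on the phenyl ring, or a longer chain in place of the present one, would read in this assay also stays open.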